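Replacing the 4-Methoxyphenyl Group of Compound 1

The compounds below may be only part of what the source reports. "The series", "measured", "known", "first", "only" and "open" are said of these compounds alone.

In a functional assay on THP-1 cells (Homo sapiens) (a lower number here means a stronger inhibitor, a higher number a weaker inhibitor), compound 1 (`CCSC[C@@](O)([C@@H](Nc1cccc2nc(C)ccc12)c1ccc(OC)cc1)C(F)(F)F`) gives 6.31 nM and compound 2 (`CCSC[C@@](O)([C@@H](Nc1cccc2nc(C)ccc12)c1ccc(OC)cc1F)C(F)(F)F`) gives 5.01 nM, so the two lie within the scatter of each other. Compound 3 (`CCSC[C@@](O)([C@@H](Nc1cccc2nc(C)ccc12)c1ccc(Cl)c(F)c1OC)C(F)(F)F`) keeps the core of compound 1 and differs from it as follows: 4-chloro-3-fluoro-2-methoxyphenyl in place of 4-methoxyphenyl on a saturated chain carbon bound to a nitrogen on an aromatic ring and a saturated chain carbon. The change sits on a saturated chain carbon bound to a nitrogen on an aromatic ring and a saturated chain carbon. For the measured compounds named here, only one measured step bears on it, fluoro in place of hydrogen on an aromatic carbon, and that is a 1.3-fold lower number from compound 1 to compound 2 (0.10 log units; within the scatter). Going by the values given here, no measured compound carries the 4-chloro-3-fluoro-2-methoxyphenyl group, so this guide is thin, and no shift beyond the scatter is expected in either direction. The expected change is a 1.3-fold lower number from compound 1 to compound 3 (0.10 log units; within the scatter). Compound 3 is estimated at 5 nM, with an expected range of 1.5 nM to 20 nM.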

Compound 3, half-maximal inhibitory concentration: 1.59 nM
The estimate for compound 3 lay 3.1-fold (0.50 log units) above the measured number, and the stated range covers the measured number.
By their numbers in this assay, from the lowest: compound 3; then compounds 2 and 1 (each within the scatter of the next).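

In this assay, a change to the aryl group on this saturated chain carbon moves the number beyond the scatter: the 4-chloro-3-fluoro-2-methoxyphenyl group gives a 4.0-fold lower number from compound 1 to compound 3 (0.60 log units; beyond the scatter), and measured against the 2-fluoro-4-methoxyphenyl group it gives a 3.2-fold lower number from compound 2 to compound 3 (0.50 log units; beyond the scatter). For the compounds shown here, the position therefore responds to a larger change in the ring's substituents, whereas the single fluoro change, a 1.3-fold lower number from compound 1 to compound 2 (0.10 log units; within the scatter), stayed within the scatter. No measurement at hand accounts for this gain.

The new group differs from 4-methoxyphenyl in more than one place, so the compounds shown do not separate what the chloro, the fluoro and the relocated methoxy each contribute. They also leave open whether the gain would persist with a nitrile or a bromo on the ring, or with a pyridine ring in place of the phenyl.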